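A Step From Compound 3 to Compound 4 at the Limit

A few compounds are considered here, and "the series" means these few. Any claim that something is new, unique, unknown or untested is made for them only; others in the source may bear on it.

Compound 3 `C=CCSc1nnc(-c2cc(OC)c(OC)c(OC)c2)n1N1C(=O)c2ccccc2C1=O` gives in a functional assay on PC-3M cells (Homo sapiens) for cytotoxicity, read by MTT assay, with a stated time of 48 h (a higher number here means a weaker inhibitor, a lower number a stronger inhibitor), only a limit, > 200000 nM, and not a number. Compound 1 `CCc1nnc(SCC(=O)c2ccccc2)n1N1C(=O)c2ccccc2C1=O` gives in this assay a limit as well, > 200000 nM. Compound 2 `CCc1nnc(SCC(=O)c2ccc(C)cc2)n1N1C(=O)c2ccccc2C1=O` likewise gives only a limit, > 200000 nM. Thus (the limit of > 200000 nM in this assay, at which 3 of the 3 values shown sit); none of the three measured compounds yields a readable number, and compound 3 stands no differently from the other two.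

Compound 4 `COc1cc(-c2nnc(SCC(=O)c3ccc(F)c(F)c3)n2N2C(=O)c3ccccc3C2=O)cc(OC)c1OC` differs from compound 3 by (3,4-difluorophenyl)carbonyl in place of vinyl on a saturated chain carbon bound to a sulfur. Among the compounds with values here, the only measured pair that differs in one place is compound 1 and compound 2, where the two limits leave the step that the two limits leave unreadable from compound 1 to compound 2 unreadable in size. No measured step therefore bears on the change from compound 3 to compound 4, and neither its direction nor its size can be drawn from what is shown.

On that basis compound 4 is expected to remain at the limit as well, with an estimated 200000 nM between 100000 nM and 400000 nM. The step of a number no higher from compound 3 to compound 4 (the limit leaves the size open) is accordingly expected to be none beyond the scatter.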

Compound 4, half-maximal inhibitory concentration: 163000 nM
The estimate for compound 4 lay 1.2-fold (0.09 log units) above the measured number, within the range that was stated.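

Putting (3,4-difluorophenyl)carbonyl in place of vinyl on a saturated chain carbon bound to a sulfur gives an at least 1.2-fold lower number from compound 3 to compound 4 (0.08 log units; that floor lies within the scatter) in this assay. Within the data shown here, with this change, compound 4 gives the first number rather than a limit, so the step has a readable floor, which the earlier compounds could not provide. Compound 3 gives only a limit, so the step has no readable upper end, and the series as a whole remains almost entirely at that limit: the limit of > 200000 nM in this assay, at which 3 of the 4 values shown sit.

As far as these compounds go, it remains open what a plain phenylcarbonyl, an amine or a carboxylic acid would give at this place on the core of compound 4. From the compounds shown here alone, it also remains open whether the same change would give a readable number on the core of compound 1.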